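Turning a hydroxy of compound 2 into methoxy

The source may hold more compounds than are shown below. What is called first, only, known or untested is meant among the compounds shown, and "the series" means these compounds.

In a functional assay (on this read-out lower numbers stand for stronger inhibition and higher numbers for weaker inhibition), compound 1 `O=C1/C(=C/c2ccc(O)c(O)c2)COc2c1ccc(O)c2O` gives 8500 nM and compound 2 `O=C1/C(=C/c2ccc(O)cc2)COc2c1ccc(O)c2O` gives 26500 nM as the higher of the two numbers, so compound 2 is the weaker inhibitor of this pair. Compound 3 `COc1ccc(/C=C2\COc3c(ccc(O)c3O)C2=O)cc1` differs from compound 2 in one place: methyl in place of hydrogen on an oxygen on an aromatic ring, which reads as hydroxy to methoxy (methyl in place of hydrogen on an oxygen on an aromatic ring). For the measured compounds named here, no measured step shows this exact change. Going by the values given here, the only step that bears on it, hydrogen in place of hydroxy on an aromatic carbon, is modest (a 3.1-fold higher number from compound 1 to compound 2 (0.49 log units; beyond the scatter)) and removes the oxygen altogether, whereas compound 3 keeps that oxygen and only adds a methyl to it. Among the compounds with values here, with that modest step as the sole guide, a similar or smaller rise in the number is expected in this assay for compound 3. The expected step is a 1.4-fold higher number from compound 2 to compound 3 (0.16 log units; within the scatter) and may well stay within the scatter. Compound 3 is estimated at 38000 nM (expected range 15000 nM to 95000 nM).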

Compound 3, half-maximal inhibitory concentration: 30100 nM
Beside the measured number, compound 3's estimate is 1.3-fold (0.10 log units) above it, within the range that was stated.
By their numbers in this assay, from the lowest: compound 1; then compounds 2 and 3 (each within the scatter of the next).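

In this assay, putting a methyl on this oxygen gives a 1.1-fold higher number from compound 2 to compound 3 (0.06 log units; within the scatter) and so leaves compound 2 and compound 3 indistinguishable on this read-out. The earlier step, a 3.1-fold higher number from compound 1 to compound 2 (0.49 log units; beyond the scatter), concerned a different hydroxy and the loss of its whole oxygen, so it could say nothing about the hydroxy that remains in compound 2. This new step adds that, for this one pair, the hydrogen on this oxygen can be exchanged for methyl with no difference beyond the scatter, which means that a free hydroxy at this place is not needed to keep the number where it stands in compound 2.

Going by these compounds, a single methyl is only the smallest replacement, so it remains open whether a longer chain such as ethyl or propyl on this oxygen, or an amine or a carboxylic acid in place of the hydroxy, would be accepted equally well. On these data alone, it is also open whether methoxy would behave in the same way on the core of compound 1, which carries the lower number. Nothing given here offers an explanation for the result.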